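This account rests on a few compounds, and the source may have more. Where it says the series, first, only, none or still open, it means among the compounds named here.

Series notes. The shared core is carried by compound 1 `CC1CCCN(C(=O)CN2CN(c3ccccc3)C3(CCN(C(=O)c4ccc(C(C)(C)C)cc4)CC3)C2=O)C1`, compound 2 `CC1(C)CC(OC(=O)CN2CN(c3ccccc3)C3(CCN(C(=O)c4ccc(C(C)(C)C)cc4)CC3)C2=O)CC(C)(C)N1`, compound 3 `COC(=O)CCCNC(=O)CN1CN(c2ccccc2)C2(CCN(C(=O)c3ccc(C(C)(C)C)cc3)CC2)C1=O` and compound 4 `CC(C)(C)c1ccc(C(=O)N2CCC3(CC2)C(=O)N(CC(=O)N2CCCCC2CO)CN3c2ccccc2)cc1`; they differ only in the group attached to the carbonyl carbon of the side chain. In an assay on HEK293 cells for displacement of a labelled ligand from NPC1-like intracellular cholesterol transporter 1 (Homo sapiens) (on this read-out higher numbers stand for weaker inhibition and lower numbers for stronger inhibition), compound 1 gives 12000 nM and compound 2 gives 1300 nM. Among the compounds with values here, the single step that can be read among the measured pairs is a 9.2-fold lower number from compound 1 to compound 2 (0.97 log units; beyond the scatter). For compound 3 the result in this assay is "not determined" (no result reported), so its standing among the measured compounds cannot be placed. The change from compound 3 to compound 4 is 2-(hydroxymethyl)piperidin-1-yl in place of (3-(methoxycarbonyl)propyl)amino on a carbonyl carbon. Within the data shown here, no measured step matches this change; the step from compound 1 to compound 2 concerns a different pair of groups and shows only that exchanging the group on this carbonyl carbon can move the result well beyond the scatter. Compound 4 carries a piperidin-1-yl group on that carbonyl carbon, as does compound 1, which gives the nearest anchor. With no value for compound 3, no direction can be assigned to the step itself; the estimate is set near compound 1 with a wide range. Compound 4 is expected to give about 8000 nM in this assay, within a range from 2000 nM to 30000 nM.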

Compound 4, half-maximal inhibitory concentration: 11800 nM
Compound 4: the middle estimate sits 1.5-fold (0.17 log units) below what was measured; the range from low to high includes it.
By their numbers in this assay, from the lowest: compound 2; then compounds 4 and 1 (each within the scatter of the next).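

In this assay, the step of a 1.0-fold lower number from compound 1 to compound 4 (0.01 log units; within the scatter) stays within the scatter, so on this carbonyl carbon 2-(hydroxymethyl)piperidin-1-yl and 3-methylpiperidin-1-yl cannot be told apart, despite the different substituent and its place on the piperidine ring. The step of a 9.1-fold higher number from compound 2 to compound 4 (0.96 log units; beyond the scatter) lies beyond the scatter, so compound 2, with its (2,2,6,6-tetramethylpiperidin-4-yl)oxy group joined through oxygen rather than through a ring nitrogen, now stands apart from two piperidin-1-yl compounds and not just from compound 1. The step from compound 3 to compound 4 cannot be read, and nothing available bears on the cause of these results.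

The compounds shown leave open whether the separation of compound 2 follows from the oxygen link or from the tetramethylpiperidine ring itself, a question that (2,2,6,6-tetramethylpiperidin-4-yl)amino on the same carbonyl carbon would address directly. Also open, on these data alone, is whether unsubstituted piperidin-1-yl or morpholin-4-yl would fall with compound 1 and compound 4, and where an open chain such as (3-(methoxycarbonyl)propyl)amino or its carboxylic acid would stand.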